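Changing the group on the sulfonyl sulfur of compound 3

This account rests on a few compounds, and the source may have more. Where it says the series, first, only, none or still open, it means among the compounds named here.

Of the compounds shown here, three sharing one core have been read in a functional assay on KB cells (Homo sapiens) for cytotoxicity; on this read-out lower numbers stand for stronger inhibition and higher numbers for weaker inhibition. Compound 1 `C/C=C/C(=O)OC1=CC(=O)c2ccccc2C1=O` gives 64200 nM, compound 2 `CCOC1=CC(=O)c2ccccc2C1=O` gives 16900 nM and compound 3 `CS(=O)(=O)OC1=CC(=O)c2ccccc2C1=O` gives 7180 nM. Compound 3 therefore holds the lowest number of the three, beyond the scatter from both of the others.

The next change keeps the sulfonyl and alters what it carries. Compound 4 `Cc1ccc(S(=O)(=O)OC2=CC(=O)c3ccccc3C2=O)cc1` has 4-methylphenyl in place of methyl on a sulfonyl sulfur.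

Within the data shown here, no measured step varies the group on the sulfonyl sulfur, so none bears on this change directly. The nearest evidence is the set of modest steps at the group on the oxygen: a 3.8-fold lower number from compound 1 to compound 2 (0.58 log units; beyond the scatter), an 8.9-fold lower number from compound 1 to compound 3 (0.95 log units; beyond the scatter) and a 2.4-fold lower number from compound 2 to compound 3 (0.37 log units; beyond the scatter). Each of these replaces the whole group on the oxygen, whereas the sulfonyl stays in place here. With so few compounds, neither direction is favoured. In this assay, no step beyond the scatter is expected, although one about as large as a 2.4-fold lower number from compound 2 to compound 3 (0.37 log units; beyond the scatter) would not be surprising.

The estimated step is a 1.2-fold lower number from compound 3 to compound 4 (0.08 log units; within the scatter). For compound 4 the expected value is 6000 nM, with an estimated range of 1800 nM to 20000 nM.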

Compound 4, half-maximal inhibitory concentration: 18800 nM
For compound 4 the middle estimate is 3.1-fold (0.50 log units) below the measured one, within the range that was stated.
By their numbers in this assay, from the lowest: compound 3; then compounds 2 and 4 (each within the scatter of the next); then compound 1.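

In this assay, among these compounds, the group on the sulfonyl sulfur proves not to be a silent position: a 2.6-fold higher number from compound 3 to compound 4 (0.42 log units; beyond the scatter) is the first step read at this place, and 4-methylphenyl in place of methyl gives up part of what compound 3 held. The earlier steps shown here each replaced the whole group on the oxygen, so they could not separate the sulfonyl from what it carries; here the sulfonyl stays and the number still moves beyond the scatter, so the sulfonyl alone does not fix the reading. The step comes with the entry of one six-membered aromatic ring and a change from 1 heavy atom to 7 heavy atoms, but nothing measured here explains why the number moves.

From the compounds shown here alone, it remains open whether the step belongs to the aromatic ring or to its methyl, a question that a plain phenyl on the sulfonyl sulfur would separate. Equally open, going by these compounds, is how a longer alkyl chain or a dimethylamino group on the sulfur would read against compound 3.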